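Trading 2,4-dimethoxyphenyl for 2,4-difluorophenyl

The compounds below may be only part of what the source reports. "The series", "measured", "known", "first", "only" and "open" are said of these compounds alone.

In a functional assay on CCRF-CEM cells (Homo sapiens) for antiproliferative activity, with a stated time of 72 h (on this read-out lower numbers stand for stronger inhibition and higher numbers for weaker inhibition), compound 2 (`COc1ccc(CNc2ncnc3c2ncn3[C@@H]2O[C@H](CO)[C@@H](O)[C@H]2O)c(OC)c1`) gives > 166000 nM, which is a limit of the assay and not a number. Compound 2 therefore stands at the limit of > 166000 nM in this assay, at which 1 of the 2 values shown sits. Going by the values given here, the only other measured compound is compound 1 (`OC[C@H]1O[C@@H](n2cnc3c(NCc4ccccc4Br)ncnc32)[C@H](O)[C@@H]1O`), and in this assay compound 1 gives 12300 nM. Compound 3 (`OC[C@H]1O[C@@H](n2cnc3c(NCc4ccc(F)cc4F)ncnc32)[C@H](O)[C@@H]1O`) keeps the shared core and differs from compound 2 in one place: 2,4-difluorophenyl in place of 2,4-dimethoxyphenyl on a saturated chain carbon bound to a nitrogen on an aromatic ring. Among the compounds with values here, one measured step bears on this change, the large and beyond-scatter an at least 13-fold higher number from compound 1 to compound 2 (1.13 log units; beyond the scatter). That step also involved the removal or arrival of 2,4-dimethoxyphenyl at the same place, so the change to compound 3 undoes the group that accompanied the loss of activity. Compound 3 instead carries 2,4-difluorophenyl, which, like the 2-bromophenyl of compound 1, has no hydrogen-bond acceptors. A large move toward lower numbers is therefore expected, though one measured step is thin support and a further limit remains possible. The expected change is an at least 5.5-fold lower number from compound 2 to compound 3 (0.74 log units; beyond the scatter). Compound 3 is estimated at 30000 nM, with an expected range of 8000 nM to 120000 nM.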

Compound 3, half-maximal inhibitory concentration: 7100 nM
Compound 3: middle estimate off by 4.2-fold (0.63 log units), on the high side, and the stated range ends above it.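

Replacing 2,4-dimethoxyphenyl with 2,4-difluorophenyl on a saturated chain carbon bound to a nitrogen on an aromatic ring gives, in this assay, an at least 23-fold lower number from compound 2 to compound 3 (1.36 log units; beyond the scatter), so activity at this place returns with the shared core unchanged. Going by these compounds, compound 2 is a limit of the assay and not a number, so the true size of that step remains unknown and only its lower bound is given: the limit of > 166000 nM in this assay, at which 1 of the 3 values shown sits. The second step, a 1.7-fold lower number from compound 1 to compound 3 (0.24 log units; within the scatter), puts 2,4-difluorophenyl and 2-bromophenyl level in this assay, which means that of the three groups seen at this place, only 2,4-dimethoxyphenyl stands apart.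

On these data alone, whether a single methoxy group on the phenyl ring goes with the same loss as the pair, or whether the loss needs both, stays open. So does the result in this assay of an unsubstituted phenyl, or of a phenyl carrying an amine or a carboxylic acid, at this place, and with it whether the halogens in compounds 1 and 3 matter at all.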